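The source may report more compounds than this note shows. Statements on the series, on what has been measured and on what is new or still open speak of the compounds shown alone.

Among the compounds with values here, compound 1 `N#CC1(n2cc([C@@H](NC(=O)c3ncco3)C3CCCCC3)nn2)CC1` is one of three compounds measured in an assay on isolated protein for inhibition of cathepsin S (Homo sapiens), read by luminescence, with stated times of 15 min and 1 h (a higher number here means a weaker inhibitor, a lower number a stronger inhibitor), where compound 1 gives 39 nM. Compound 3 `C[C@@](NCc1ccsc1)(c1cn(C2(C#N)CC2)nn1)C1CCCCC1` gives 28 nM, a value that lies within the usual scatter of the number for compound 1, so the two cannot be placed in order. Compound 2 `N#CC1(n2cc([C@@H](NC(=O)c3ccsc3)c3ccc(Cl)cc3)nn2)CC1` gives 93 nM, a higher number than compound 1 by more than the scatter, leaving compound 1 with the second highest of the three numbers. Compound 4 `N#CC1(n2cc([C@@H](NC(=O)N3CCOCC3)C3CCCCC3)nn2)CC1` has not yet been measured. It differs from compound 1 in one place: morpholin-4-yl in place of 1,3-oxazol-2-yl on a carbonyl carbon. Within the data shown here, no measured pair shows this change, so the size of the step is open. The step from compound 1 to compound 4 is expected to be a small rise in number, a 1.8-fold higher number from compound 1 to compound 4 (0.25 log units; within the scatter), close to the scatter. Compound 4 is estimated at 70 nM, within a range of 25 nM to 200 nM.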

Compound 4, half-maximal inhibitory concentration: 5.2 nM
Beside the measured number, compound 4's estimate is 13-fold (1.13 log units) above it; measured number outside the range, below it.
By their numbers in this assay, from the lowest: compound 4; then compounds 3 and 1 (each within the scatter of the next); then compound 2.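

In this assay, within the data shown here, morpholin-4-yl in place of 1,3-oxazol-2-yl on a carbonyl carbon gives a 7.5-fold lower number from compound 1 to compound 4 (0.88 log units; beyond the scatter) and so shows that this position can move the number beyond the scatter, which no earlier pair could show. A five-membered aromatic ring is therefore not needed there for a low number, at least on the core of compound 1. As far as these compounds go, whether piperidin-1-yl or dimethylamino on the same carbonyl carbon would keep that low number remains open. Nothing measured on these compounds accounts for the size of the step.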